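The source may hold more compounds than are shown below. What is called first, only, known or untested is meant among the compounds shown, and "the series" means these compounds.

Compound 1 `COc1cc(-c2nccn2C(C)C)cc(OC)c1OC`, compound 2 `COc1cc(-c2nccn2CC(C)C)cc(OC)c1OC` and compound 3 `COc1cc(-c2nccn2Cc2ccccc2)cc(OC)c1OC` share one core and differ only in the group on an aromatic nitrogen. In a functional assay on T47D cells (Homo sapiens) for antiproliferative activity, read by MTT assay, with a stated time of 72 h (a lower number here means a stronger inhibitor, a higher number a weaker inhibitor), compound 1 gives > 100000 nM, a limit and not a number. Compound 2 gives > 100000 nM, also a limit. Compound 3 gives > 100000 nM, again a limit. Compound 3 therefore has no number of its own, and the series sits at the limit of > 100000 nM in this assay, at which 3 of the 3 values shown sit.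

Compound 4 `COc1cc(-c2nccn2-c2cccc(C)c2)cc(OC)c1OC` carries 3-methylphenyl in place of benzyl on an aromatic nitrogen. The nearest measured changes on that nitrogen are a step that the two limits leave unreadable from compound 1 to compound 3, a step that the two limits leave unreadable from compound 2 to compound 3 and a step that the two limits leave unreadable from compound 1 to compound 2, so none gives a size to carry over. In this assay, at most a modest move towards stronger inhibition is expected, and compound 4 may well stay at the limit. The expected change is an at least 1.6-fold lower number from compound 3 to compound 4 (0.22 log units; that floor lies within the scatter). For compound 4 the estimated value is 60000 nM, with an expected range from 10000 nM to 150000 nM.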

Compound 4, half-maximal inhibitory concentration: 29300 nM
Estimate against measurement, compound 4: 2.0-fold (0.31 log units) above; the measured number falls inside the stated range.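

In this assay, the group on this nitrogen can move the result: 3-methylphenyl gives an at least 3.4-fold lower number from compound 3 to compound 4 (0.53 log units; beyond the scatter), even though benzyl and 3-methylphenyl have the same atoms, joined differently. It also gives the first readable steps from the two open-chain groups, an at least 3.4-fold lower number from compound 2 to compound 4 (0.53 log units; beyond the scatter) and an at least 3.4-fold lower number from compound 1 to compound 4 (0.53 log units; beyond the scatter). Compound 1, compound 2 and compound 3 remain limits and not numbers: the limit of > 100000 nM in this assay, at which 3 of the 4 values shown sit.

Still open, on these data alone, is how plain phenyl would compare on this nitrogen. The same goes for a phenyl ring bearing methoxy or an amine in place of the methyl.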